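The source may hold more compounds than are shown below. What is called first, only, known or untested is meant among the compounds shown, and "the series" means these compounds.

Compound 1 `N#CC1=C(N)Oc2c(c3nc4ccccc4nc3c3ccccc23)C12C(=O)N(Cc1cnnn1-c1cccc(Br)c1)c1ccccc12` was measured in a functional assay on HCT-116 cells (Homo sapiens) for antiproliferative activity, read by MTT assay, with a stated time of 48 h; a lower number here means a stronger inhibitor, a higher number a weaker inhibitor; there compound 1 gives > 50000 nM, which is a limit of the assay and not a number.
Compound 2 `CC(=O)Nc1ccc(-n2nncc2CN2C(=O)C3(C(C#N)=C(N)Oc4c3c3nc5ccccc5nc3c3ccccc43)c3ccccc32)cc1`: in this assay compound 2 gives > 50000 nM, again only a limit.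
Compound 3 `N#CC1=C(N)Oc2c(N)cc3nc4ccccc4nc3c2C12C(=O)N(Cc1cnnn1-c1ccc(F)cc1)c1ccccc12`: in this assay compound 3 gives > 50000 nM, also a limit.

Compound 3 therefore stands at the limit of > 50000 nM in this assay, at which 3 of the 3 values shown sit, with no number of its own. Compound 4 `N#CC1=C(N)Oc2c(N)cc3nc4ccccc4nc3c2C12C(=O)N(Cc1cnnn1-c1ccc(Cl)cc1Cl)c1ccccc12` differs from it by 2,4-dichlorophenyl in place of 4-fluorophenyl on an aromatic nitrogen. Among the compounds with values here, the one comparable change, a step that the two limits leave unreadable from compound 1 to compound 2, joins two limits and gives no readable size, so no measured step speaks for a shift in either direction. For compound 4 the estimate in this assay is 50000 nM, between 15000 nM and 150000 nM, which is expected to mean a number no higher from compound 3 to compound 4 (the limit leaves the size open) and most likely once more only a limit.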

Compound 4, half-maximal inhibitory concentration: > 50000 nM
Compound 4 ended at the assay's limit; the forecaster's own chance of this, stated with the estimate: 80%; the middle value lies on the limit itself.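

In this assay compound 4 gives > 50000 nM, a limit and not a number, and compound 3 also sits at a limit, so no step can be read between compound 3 and compound 4. The compounds shown leave open what size of effect, if any, either aryl group has.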